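A few compounds are considered here, and "the series" means these few. Any claim that something is new, unique, unknown or untested is made for them only; others in the source may bear on it.

Within the data shown here, in a functional assay on COLO 205 cells (Homo sapiens) for inhibition, read by sulforhodamine B assay, with a stated time of 48 h, tested at 50 uM (on this read-out lower numbers stand for less inhibition of growth and higher numbers for more inhibition of growth at the one concentration tested), compound 1 (`COc1cc(/C=C/C(=O)/C=C/c2cc(OC)c(OC)c(OC)c2)ccc1OCc1cn(CCOc2cc(=O)oc3ccccc23)nn1`) gives 86%, and compound 2 (`COc1cc(/C=C/C(=O)/C=C/c2ccco2)ccc1OCc1cn(CCOc2cc(=O)oc3ccccc23)nn1`) gives 68%, the lower of the two numbers known so far. Compound 3 (`COc1ccc(/C=C/C(=O)/C=C/c2ccc(OCc3cn(CCOc4cc(=O)oc5ccccc45)nn3)c(OC)c2)cc1`) differs from compound 2 in one group, with 4-methoxyphenyl in place of furan-2-yl on a double-bonded chain carbon bound to a double-bonded chain carbon. Among the measured compounds shown here, one measured step bears on this change: a number 18 percentage points lower from compound 1 to compound 2 (beyond the scatter), with furan-2-yl in place of 3,4,5-trimethoxyphenyl at that same place. Compound 3 returns to a six-membered aromatic ring of carbon only, as in compound 1 at 86%, but as 4-methoxyphenyl rather than 3,4,5-trimethoxyphenyl. A rise in this assay is therefore expected, probably smaller than the measured step. The expected step is a number 8 percentage points higher from compound 2 to compound 3 (within the scatter). Compound 3 is estimated at 76%, with an expected range from 62% to 90%.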

Compound 3, percent growth inhibition at one concentration: 68%
Compound 3: middle estimate off by 8 percentage points, on the high side; low and high end bracket the measured number.
By their numbers in this assay, from the lowest: compounds 2 and 3 (each within the scatter of the next); then compound 1.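

In this assay, the exchange of furan-2-yl for 4-methoxyphenyl on a double-bonded chain carbon bound to a double-bonded chain carbon gives no change at the digits printed from compound 2 to compound 3 (within the scatter), so the five-membered and six-membered aromatic rings are not told apart here. The other comparison at this place gives a number 18 percentage points lower from compound 1 to compound 3 (beyond the scatter), which shows that a six-membered aromatic ring of carbon only does not by itself match compound 1, and that among these three compounds only compound 1, with 3,4,5-trimethoxyphenyl, stands apart. Nothing given here accounts for these numbers.

The compounds shown leave open whether all the methoxy groups of 3,4,5-trimethoxyphenyl are needed for the number of compound 1. They also leave open what a phenyl ring carrying an amine or a carboxylic acid would give at this place.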